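Swapping isopropyl for acetyl on the anilino ring

This account rests on a few compounds, and the source may have more. Where it says the series, first, only, none or still open, it means among the compounds named here.

Compound 1 `C=C(OCC)c1ccc(Nc2cccc3c2C(=O)N(C2CCC(=O)NC2=O)C3=O)cc1` and compound 2 `CC(C)c1ccc(Nc2cccc3c2C(=O)N(C2CCC(=O)NC2=O)C3=O)cc1` share one core and differ only at the para position of the aniline ring. In an assay on FRT-Jurkat cells for inhibition of nuclear factor NF-kappa-B complex (Homo sapiens), read by flow cytometry, with a stated time of 24 h, tested at 10 uM (a higher number here means more inhibition at the concentration tested (going by the name of the read-out), a lower number less inhibition), compound 1 gives 10%, and compound 2 gives 19%; the step of a number 9 percentage points higher from compound 1 to compound 2 (within the scatter) lies within the scatter, so the two numbers are level. Compound 3 `CC(=O)c1ccc(Nc2cccc3c2C(=O)N(C2CCC(=O)NC2=O)C3=O)cc1` carries the change (acetyl in place of isopropyl on an aromatic carbon). Among the measured compounds shown here, only one measured step bears on it, and that step was small. A step of about a number 4 percentage points lower from compound 2 to compound 3 (within the scatter) is therefore expected, with no change beyond the scatter. Compound 3 is estimated at 15%, between 0% and 35%.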

Compound 3, a percentage reported as inhibition, at one concentration (the size of the read-out at that concentration, not a potency): 2%
The estimate for compound 3 lay 13 percentage points above the measured number; measured number inside the range.
By their numbers in this assay, from the lowest: compounds 3, 1 and 2 (each within the scatter of the next, the first and the last beyond it).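

Among the compounds shown here, with acetyl in place of isopropyl, this assay shows a number 17 percentage points lower from compound 2 to compound 3 (beyond the scatter) and so gives the first step at this position beyond the scatter, though a modest one. Acetyl in place of 1-ethoxyethenyl gives a number 8 percentage points lower from compound 1 to compound 3 (within the scatter) and leaves those two level, so the numbers separate isopropyl from acetyl but neither of them from 1-ethoxyethenyl.

Going by these compounds, whether an amine or a carboxylic acid on this carbon would sit near isopropyl, near acetyl or elsewhere stays open. Nothing on hand says why the number falls with acetyl.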